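A few compounds are considered here, and "the series" means these few. Any claim that something is new, unique, unknown or untested is made for them only; others in the source may bear on it.

Compounds measured so far in a functional assay for agonist activity at G protein-coupled receptor 88 (Homo sapiens), read by HTRF and cAMP accumulation; on this read-out lower numbers stand for an effect already at smaller amounts and higher numbers for an effect only at larger amounts of compound:
- compound 1 `CC(C)C[C@H](N)CN(C(=O)[C@@H]1C[C@H]1c1ccccc1)c1ccc(-c2ccoc2)cc1` gives 2000 nM
- compound 2 `CC(C)C[C@H](N)CN(C(=O)[C@@H]1C[C@H]1c1ccccc1)c1ccc(C2=CCCCCC2)cc1` gives 2100 nM

Among the compounds with values here, compound 2 is one of only two compounds with a number in this assay, and the single measured step, a 1.1-fold higher number from compound 1 to compound 2 (0.02 log units; within the scatter), shows that it stands at the same level as compound 1. The step to the unmeasured compound 3 `Cc1ccccc1-c1ccc(N(C[C@@H](N)CC(C)C)C(=O)[C@@H]2C[C@H]2c2ccccc2)cc1` is 2-methylphenyl in place of cyclohept-1-en-1-yl on an aromatic carbon. Within the data shown here, no measured pair carries this exact change, so the only step that bears on it is the one from furan-3-yl to cyclohept-1-en-1-yl at the same position, a 1.1-fold higher number from compound 1 to compound 2 (0.02 log units; within the scatter), which is within the scatter. Two different substituents at this position have thus given numbers that cannot be told apart, and a third group of the same size, 2-methylphenyl, is therefore expected to leave the number in this assay essentially where it is, with no step beyond the scatter in either direction. On this basis the expected step from compound 2 to compound 3 is a 1.1-fold lower number from compound 2 to compound 3 (0.02 log units; within the scatter). Compound 3 is accordingly estimated at 2000 nM in this assay, within a range from 700 nM to 6000 nM.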

Compound 3, half-maximal effective concentration: 3400 nM
The estimate for compound 3 lay 1.7-fold (0.23 log units) below the measured number; the range from low to high includes it.
By their numbers in this assay, from the lowest: compounds 1, 2 and 3 (each within the scatter of the next).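

In this assay the change from a seven-membered non-aromatic ring to a six-membered aromatic ring of carbon only, with the same number of heavy atoms, gives a 1.6-fold higher number from compound 2 to compound 3 (0.21 log units; within the scatter) and so stays within the scatter. Within the data shown here, the replacement of furan-3-yl by 2-methylphenyl gives a 1.7-fold higher number from compound 1 to compound 3 (0.23 log units; within the scatter) and is also within the scatter, so at this place, para to a large group, three rings that differ in size, in aromatic character and in the presence of a ring oxygen cannot be told apart in this read-out, which the single earlier step between two groups could not show. No measurement at hand gives a reason for this lack of separation between the three groups.

All three groups are rings without a hydrogen-bond donor, so the compounds shown leave open whether an amine, a carboxylic acid or an open hexyl chain at the same place would move the number beyond the scatter. They also leave open whether any change in the rest of the shared core, which is the same in all three compounds, would do so.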